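Pyridin-3-yl in place of benzyloxy: clearance notes

The source may hold more compounds than are shown below. What is called first, only, known or untested is meant among the compounds shown, and "the series" means these compounds.

Values in an ADME assay on microsomes (Mus musculus) for metabolic stability (on this read-out lower numbers stand for slow clearance and higher numbers for fast clearance), on the shared core
- compound 1 `CNC(=O)[C@@H]1CCCN1S(=O)(=O)c1ccc(Cl)c(COc2cccc3c(-c4cncn4C)cc(C)nc23)c1Cl` gives 117 mL/min/kg
- compound 2 `CNC(=O)[C@@H]1CCCN1S(=O)(=O)c1ccc(Cl)c(COc2cccc3c(-c4nccn4C)cc(C)nc23)c1Cl` gives 917 mL/min/kg
- compound 3 `CNC(=O)[C@@H]1CCCN1S(=O)(=O)c1ccc(Cl)c(COc2cccc3c(OCc4ccccc4)cc(C)nc23)c1Cl` gives 1820 mL/min/kg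

Compound 3 sits at the top of these three numbers. Its nearest gap is a 2.0-fold higher number from compound 2 to compound 3 (0.30 log units; within the scatter), and its furthest is a 16-fold higher number from compound 1 to compound 3 (1.19 log units; beyond the scatter).

Compound 4 `CNC(=O)[C@@H]1CCCN1S(=O)(=O)c1ccc(Cl)c(COc2cccc3c(-c4cccnc4)cc(C)nc23)c1Cl` brings (pyridin-3-yl in place of benzyloxy on an aromatic carbon), with pyridin-3-yl in place of benzyloxy on an aromatic carbon. Those same two steps bear on it when read in reverse, one within the scatter and one large. Choice of ring alone also spans a 7.8-fold higher number from compound 1 to compound 2 (0.89 log units; beyond the scatter), so the outcome stays open. The expected move in this assay is downward, with a size of a 4.0-fold lower number from compound 3 to compound 4 (0.61 log units; beyond the scatter). Compound 4 is estimated at 450 mL/min/kg, with an expected range of 130 mL/min/kg to 1500 mL/min/kg.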

Compound 4, clearance: 700 mL/min/kg
Compound 4: middle estimate off by 1.6-fold (0.19 log units), on the low side; low and high end bracket the measured number.
By their numbers in this assay, from the lowest: compound 1; then compounds 4, 2 and 3 (each within the scatter of the next, the first and the last beyond it).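

In this assay pyridin-3-yl, attached directly to the shared core, improves on benzyloxy (a 2.6-fold lower number from compound 3 to compound 4 (0.41 log units; beyond the scatter)). It cannot be separated from 1-methyl-1H-imidazol-2-yl (a 1.3-fold lower number from compound 2 to compound 4 (0.12 log units; within the scatter)) and stays well short of 1-methyl-1H-imidazol-5-yl (a 6.0-fold higher number from compound 1 to compound 4 (0.78 log units; beyond the scatter)), so among these four compounds only the group in compound 1 gives slow clearance. Nothing available accounts for these gaps.

As far as these compounds go, whether an amine or a carboxylic acid on the pyridine ring would bring clearance closer to that of compound 1 remains open, as does the effect of a saturated ring such as morpholine at this position.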